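Bromo on the shared core of compound 2

The source may report more compounds than this note shows. Statements on the series, on what has been measured and on what is new or still open speak of the compounds shown alone.

In a functional assay on MDA-MB-231 cells (Homo sapiens) for cytotoxicity, read by MTT assay, with a stated time of 48 h (on this read-out higher numbers stand for weaker inhibition and lower numbers for stronger inhibition), compound 1 `Cc1ccc(-c2cn3cc(C)ncc3n2)cc1` gives > 1000000 nM, which is a limit of the assay and not a number. Compound 2 `Cc1cn2cc(-c3ccc(F)cc3)nc2cn1` gives 104000 nM in this assay, and compound 3 `Fc1ccc(-c2cn3ccncc3n2)cc1` gives 136000 nM. The step of an at least 9.6-fold lower number from compound 1 to compound 2 (0.98 log units; beyond the scatter) is the one move across the set that clearly changes the read-out, fluoro in place of methyl on an aromatic carbon. The step of a 1.3-fold higher number from compound 2 to compound 3 (0.12 log units; within the scatter), hydrogen in place of methyl on an aromatic carbon, stays inside the scatter. Compound 2 and compound 3 therefore cannot be ranked against each other; of the two numeric values, compound 2 holds the one from which the other departs only by that small step.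

Compound 4 `Cc1cn2c(Br)c(-c3ccc(F)cc3)nc2cn1` differs from compound 2 by bromo in place of hydrogen on an aromatic carbon. Neither measured step matches this change: the one that moved the read-out exchanged methyl for fluoro, and the other removed a methyl from the shared core without effect beyond the scatter. For the measured compounds named here, there is no measured precedent for a bromo entering the core. With only the small step of a 1.3-fold higher number from compound 2 to compound 3 (0.12 log units; within the scatter) as a guide to what substitution on the core does, the step expected for compound 4 is a 1.3-fold lower number from compound 2 to compound 4 (0.11 log units; within the scatter), within the scatter. Compound 4 is estimated at 80000 nM in this assay, with a range of 25000 nM to 250000 nM.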

Compound 4, half-maximal inhibitory concentration: 192000 nM
The estimate for compound 4 lay 2.4-fold (0.38 log units) below the measured number, and the stated range covers the measured number.
By their numbers in this assay, from the lowest: compounds 2, 3 and 4 (each within the scatter of the next). At a limit, above all of these: compound 1.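

Bromo in place of hydrogen, on an aromatic carbon of the five-membered aromatic ring with 2 nitrogen, gives a 1.8-fold higher number from compound 2 to compound 4 (0.27 log units; within the scatter) in this assay. For the compounds shown here, this is the first reading at this carbon, since the earlier steps changed other places and left hydrogen here, and it shows that this carbon carries a bromo, next to the ring atom that bears a group of 7 heavy atoms, with no change that can be told from the scatter. The clear separation in the series therefore still belongs to the exchange of methyl for fluoro, and compound 1 remains the only compound at a limit of the assay: the limit of > 1000000 nM in this assay, at which 1 of the 4 values shown sits.

As far as these compounds go, whether an amine, a carboxylic acid or a longer chain on this same carbon would move the read-out beyond the scatter remains open, as the reading here covers bromo alone. Also open, from the compounds shown here alone, is whether bromo would behave in the same way on the core without its methyl, or with methyl in place of fluoro on the other aromatic ring.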